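A few compounds are considered here, and "the series" means these few. Any claim that something is new, unique, unknown or untested is made for them only; others in the source may bear on it.

Measured in a functional assay on A-375 cells (Homo sapiens) for antiproliferative activity, read by CCK-8 assay, with a stated time of 72 h; a lower number here means a stronger inhibitor, a higher number a weaker inhibitor:
- compound 1 `Nc1ccccc1NC(=O)c1ccc(CSC(=S)N2CCc3ccccc32)cc1`: 4050 nM
- compound 2 `Nc1ccccc1NC(=O)c1ccc(CSC(=S)N2CCN(c3ccc(F)cc3)CC2)cc1`: 9400 nM
- compound 3 `Nc1ccccc1NC(=O)c1ccc(CSC(=S)N2CCc3cc(Cl)ccc32)cc1`: 5280 nM

The value of compound 3 lies within the scatter of those of compound 1 and compound 2. Compound 4 `CC1CCCCN1C(=S)SCc1ccc(C(=O)Nc2ccccc2N)cc1`, not yet measured, carries 2-methylpiperidin-1-yl in place of 5-chloro-2,3-dihydro-1H-indol-1-yl on a thiocarbonyl carbon.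

Among the measured compounds shown here, only one measured step bears on this group: a 1.3-fold higher number from compound 1 to compound 3 (0.12 log units; within the scatter). It lies within the scatter and exchanges only chloro for hydrogen, so it gives weak guidance for replacing the entire group. In this assay the expected change is no more than scatter, a 1.1-fold higher number from compound 3 to compound 4 (0.06 log units; within the scatter). For compound 4 the estimated value is 6000 nM, with an expected range of 2500 nM to 14000 nM.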

Compound 4, half-maximal inhibitory concentration: 2610 nM
The estimate for compound 4 lay 2.3-fold (0.36 log units) above the measured number; the measured number falls inside the stated range.
By their numbers in this assay, from the lowest: compounds 4, 1, 3 and 2 (each within the scatter of the next, the first and the last beyond it).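

In this assay the thiocarbonyl carbon accepts a group with no aromatic ring: 2-methylpiperidin-1-yl gives a 2.0-fold lower number from compound 3 to compound 4 (0.31 log units; beyond the scatter) and thus a modest gain. Against 2,3-dihydro-1H-indol-1-yl the same group gives a 1.6-fold lower number from compound 1 to compound 4 (0.19 log units; within the scatter) and so shows no real difference, which means the gain holds only against the chlorinated group. Nothing available explains this step.

As far as these compounds go, what piperidin-1-yl without its methyl would give at this carbon stays open, so the part played by the methyl is unknown. A morpholin-4-yl or an open-chain diethylamino group at this carbon also remains untested among the compounds shown.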